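The source may report more compounds than this note shows. Statements on the series, on what has been measured and on what is new or still open speak of the compounds shown alone.

Measured so far in a functional assay on MDA-MB-435 cells (Homo sapiens) for cytotoxicity, read by sulforhodamine B assay, with a stated time of 48 h; a lower number here means a stronger inhibitor of growth, a higher number a weaker inhibitor of growth:
compound 1, `ClCc1ccccc1Cn1cnc2c(Cl)nc(Cl)nc21`, gives 1620 nM.
compound 2, `ClCc1ccccc1Cn1cnc2c(Cl)ncnc21`, gives 3020 nM.
compound 3, `ClCc1cccc(Cn2cnc3ncnc(Cl)c32)c1`, gives 3460 nM.

Compounds 2 and 3 are built from the same atoms joined differently; the difference between the two cores is not broken down here. Their numbers in this assay lie within the scatter of each other, so no order between them is claimed. Compound 1 differs from compound 2 by chloro in place of hydrogen on an aromatic carbon, and a 1.9-fold lower number from compound 2 to compound 1 (0.27 log units; within the scatter). Compound 3 stands beyond the scatter only from compound 1.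

Compound 4, `ClCc1cccc(Cn2cnc3nc(Cl)nc(Cl)c32)c1`, has not yet been measured. Among the measured compounds shown here, it differs from compound 3 by chloro in place of hydrogen on an aromatic carbon, which is the same change at the same kind of place as the one separating compound 2 from compound 1. The expectation for the step from compound 3 to compound 4 is therefore a 1.8-fold lower number from compound 3 to compound 4 (0.26 log units; within the scatter), resting on that single earlier instance, so confidence is limited and the range kept wide. In this assay compound 4 is expected to give about 1900 nM, most likely between 900 nM and 4000 nM.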

Compound 4, concentration for 50% growth inhibition: 1470 nM
Compound 4: the middle estimate sits 1.3-fold (0.11 log units) above what was measured; low and high end bracket the measured number.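

In this assay, chloro in place of hydrogen on an aromatic carbon, between two ring nitrogen atoms, gives a 2.4-fold lower number from compound 3 to compound 4 (0.37 log units; beyond the scatter). The step on the core of compound 3 therefore stands beyond the scatter, while the earlier step on the core of compound 2 does not, yet the two steps cannot be told apart in size: the same change on two cores in this assay, a 1.9-fold lower number (0.27 log units; within the scatter) from compound 2 to compound 1 and a 2.4-fold lower number (0.37 log units; beyond the scatter) from compound 3 to compound 4, 1.3-fold (0.10 log units) apart, within the scatter of two such steps. This fits the change carrying across these two cores with a similar size, but two instances set no general rule for the series and do not show why the number shifts or how the change would act on any other core.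

As far as these compounds go, whether an amine or a methoxy group in place of this chloro would give a number close to those of compound 1 and compound 4 remains open. Also open, from the compounds shown here alone, is whether a longer chain or a carboxylic acid at the same ring carbon would be tolerated in this assay.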